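The source may report more compounds than this note shows. Statements on the series, on what has been measured and on what is new or still open speak of the compounds shown alone.

Measured so far:
compound 1 `Cn1c(-c2ccccc2)cnc1NC(=O)c1ccc(F)cc1` — > 100000 nM
compound 2 `COc1ccc(-c2cn(C)c(NC(=O)c3ccc(F)cc3)n2)cc1` — > 50000 nM
compound 3 `COc1cccc(-c2cnc(NC(=O)c3ccc(F)cc3)n2C)c1` — > 100000 nM

All three were tested in a toxicity assay on THP-1 cells (Homo sapiens) for inhibition; on this read-out lower numbers stand for higher toxicity in this test and higher numbers for lower toxicity in this test. None gave a number. Compound 1 reached only a limit of the test. Compound 3 also reached only a limit. Compound 2 likewise reached only a limit, though a lower one. The change from compound 3 to compound 1 is hydrogen in place of methoxy on an aromatic carbon; the step it made, a step that the two limits leave unreadable from compound 3 to compound 1, cannot be sized because both values sit at the limit of > 100000 nM in this assay, at which 2 of the 3 values shown sit.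

Compound 4 `Cn1cc(-c2ccccc2)nc1NC(=O)c1ccc(F)cc1` differs from compound 2 by hydrogen in place of methoxy on an aromatic carbon. This is the same kind of change as from compound 3 to compound 1, but here the place is para to a large group, there meta to a large group. How the cores of compound 2 and compound 3 differ is not broken down here.

For compound 4, the expected step from compound 2 is a step that the limit leaves unreadable from compound 2 to compound 4, resting on compound 2 at the limit of > 50000 nM in this assay, at which 1 of the 3 values shown sits, and on the unreadable step above. Compound 4 is therefore estimated at 150000 nM, expected between 40000 nM and 600000 nM.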

Compound 4, half-maximal cytotoxic concentration: > 50000 nM
Compound 4 was reported as a limit; the forecaster's own chance of this, stated with the estimate: 85%; the middle value does not contradict the limit.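

No step can be read from compound 2 to compound 4, because each of the two compounds reached only a limit of the test: the limit of > 50000 nM in this assay, at which 2 of the 4 values shown sit.

The compounds shown leave open whether hydrogen in place of methoxy, at either place on the aromatic ring, changes the result in this assay, and at what concentration any of the four compounds would become toxic.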